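A few compounds are considered here, and "the series" means these few. Any claim that something is new, unique, unknown or untested is made for them only; others in the source may bear on it.

Compound 1 `COC(=O)C(c1ccccc1)n1nnnc1[C@@H](COCc1ccccc1)NC(=O)C(C)(C)N`: 470 nM
Compound 2 `CC(C)(N)C(=O)N[C@H](COCc1ccccc1)c1nnnn1CC#N`: 4170 nM
Compound 3 `CC(C)(N)C(=O)N[C@H](COCc1ccccc1)c1nnn(CCCc2ccccc2NS(C)(=O)=O)n1`: 2390 nM

All three were tested in an assay on isolated protein for displacement of a labelled ligand from growth hormone secretagogue receptor type 1 (Homo sapiens), with a stated time of 1 h; a lower number here means a stronger inhibitor, a higher number a weaker inhibitor. Compound 2 gives the highest of the three numbers; compound 3 lies nearest to it, within the usual scatter, while compound 1 lies furthest from it, beyond the scatter. Within the data shown here, the one measured step that changes a single place, an 8.9-fold higher number from compound 1 to compound 2 (0.95 log units; beyond the scatter), concerns the group on the aromatic nitrogen together with the ester, not the point of attachment of the ring itself.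

Compound 4 `CC(C)(N)C(=O)N[C@H](COCc1ccccc1)c1nnn(CC#N)n1` is not yet measured. It differs from compound 2 only in how the same atoms are joined: 2-(cyanomethyl)-2H-tetrazol-5-yl in place of 1-(cyanomethyl)-1H-tetrazol-5-yl on a saturated chain carbon bound to an amide-type nitrogen and a saturated chain carbon. Among the measured compounds shown here, no measured step bears directly on this change. For the measured compounds named here, compound 3 also carries the ring attached in this second manner, and its value and that of compound 2 are within the scatter of each other, but compound 3 also carries a different substituent, so its value shows only that such a ring can sit at a similar level. Compound 4 is therefore expected to show no step beyond the scatter, a 1.2-fold lower number from compound 2 to compound 4 (0.08 log units; within the scatter), in this assay. The estimate for compound 4 is 3500 nM, within the range 1200 nM to 10000 nM.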

Compound 4, inhibition constant: > 5000 nM
Compound 4 ended at the assay's limit (the forecaster's own chance of this, stated with the estimate: 5%); middle value at least 1.4-fold (0.15 log units) away from the limit.
By their numbers in this assay, from the lowest: compound 1; then compounds 3 and 2 (each within the scatter of the next). At a limit, above all of these: compound 4.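

Compound 4 gives > 5000 nM in this assay, which is a limit of the assay and not a number: the limit of > 5000 nM in this assay, at which 1 of the 4 values shown sits.

Joining the same atoms as 2-(cyanomethyl)-2H-tetrazol-5-yl in place of 1-(cyanomethyl)-1H-tetrazol-5-yl gives an at least 1.1-fold higher number from compound 2 to compound 4 (0.07 log units; that floor lies within the scatter), the first direct reading of this change at this position, and it brings no lower number. Only a floor of the step can be read, and that floor lies within the scatter, so the change cannot be called either a real loss or a negligible one.

The compounds shown leave open how large the step truly is. They also leave open whether the two ways of joining the ring would compare in the same way with an amine, a carboxylic acid or a longer chain in place of the cyanomethyl group.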